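The source may report more compounds than this note shows. Statements on the series, on what has been measured and on what is new or still open speak of the compounds shown alone.

Among the measured compounds shown here, compound 2 `CN(C)C(=O)c1cc2cnc(Nc3ccc(C(=O)NCCCCCN=C=S)cc3)nc2n1C1CCCC1` gives 76.5% in a functional assay on NCI-H1299 cells (Homo sapiens) for inhibition, read by CCK-8 assay, with a stated time of 72 h, tested at 10 uM (on this read-out lower numbers stand for a weaker effect and higher numbers for a stronger effect at the one concentration tested), and is one of only two compounds measured; the other, compound 1 `CN(C)C(=O)c1cc2cnc(Nc3ccc(S(=O)(=O)NCCCCN=C=S)cc3)nc2n1C1CCCC1`, gives 72.7% in this assay, and the step of a number 3.8 percentage points higher from compound 1 to compound 2 (within the scatter) lies within the scatter, so the two numbers cannot be told apart. Compound 3 `CN(C)C(=O)c1cc2cnc(Nc3ccc(C(=O)NCCCCCN=C=S)cc3F)nc2n1C1CCCC1` has not yet been measured. It differs from compound 2 by fluoro in place of hydrogen on an aromatic carbon. For the measured compounds named here, the single measured step, a number 3.8 percentage points higher from compound 1 to compound 2 (within the scatter), concerns the exchange of one chain for another on the shared core and does not touch the aromatic ring that receives the fluoro group, so no measured step bears directly on this change. With nothing pointing to a shift beyond the scatter, compound 3 is expected to land close to compound 2, the estimated step being a number 0.5 percentage points lower from compound 2 to compound 3 (within the scatter). The estimate for compound 3 is 76%, within a range from 60% to 90%.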

Compound 3, a percentage reported as inhibition, at one concentration (the size of the read-out at that concentration, not a potency): 86.7%
Beside the measured number, compound 3's estimate is 10.7 percentage points below it, within the range that was stated.
By their numbers in this assay, from the lowest: compounds 1 and 2 (each within the scatter of the next); then compound 3.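

In this assay, the six-membered aromatic ring of carbon only turns out to respond to a change of a single atom: fluoro in place of hydrogen on an aromatic carbon, ortho to a large group and meta to a large group, gives a number 10.2 percentage points higher from compound 2 to compound 3 (beyond the scatter) and so moves the number beyond the scatter, if modestly. The earlier pair differed only in the chain, and that exchange left the two numbers indistinguishable, so this is the first change in the series shown to register at all, and it does so on the ring rather than on the chain. No evidence on hand accounts for the gain.

The compounds shown leave open whether chloro, methyl or methoxy on this carbon would do the same, and whether fluoro on another carbon of this ring would. They also leave open whether fluoro has this effect alongside the chain of compound 1, and how a gain at one concentration relates to potency.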